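Extending isopropoxy to tert-butoxy on an amidine-bearing core

The source may hold more compounds than are shown below. What is called first, only, known or untested is meant among the compounds shown, and "the series" means these compounds.

Three compounds share a core and differ at one aromatic position. In a functional assay for inhibition of sodium/hydrogen exchanger (Oryctolagus cuniculus) (on this read-out higher numbers stand for weaker inhibition and lower numbers for stronger inhibition), compound 1 `Cc1cc(SC(C)(C)C)c(S(C)(=O)=O)cc1C(=O)N=C(N)N` gives 22 nM, compound 2 `Cc1cc(Sc2cccc(Cl)c2)c(S(C)(=O)=O)cc1C(=O)N=C(N)N` gives 37 nM, and compound 3 `Cc1cc(OC(C)C)c(S(C)(=O)=O)cc1C(=O)N=C(N)N` gives 19 nM. Compound 3 sits at one end of these numbers, yet the steps of a 1.2-fold lower number from compound 1 to compound 3 (0.06 log units; within the scatter) and a 1.9-fold lower number from compound 2 to compound 3 (0.29 log units; within the scatter) both fall within the scatter, so no ranking is claimed. Compound 4 `Cc1cc(OC(C)(C)C)c(S(C)(=O)=O)cc1C(=O)N=C(N)N` carries methyl in place of hydrogen on a saturated chain carbon bound to an oxygen on an aromatic ring and two saturated chain carbons. The closest comparison is the step of a 1.2-fold lower number from compound 1 to compound 3 (0.06 log units; within the scatter), where a tert-butyl on sulfur and an isopropyl on oxygen gave nearly the same number. A change of similar scale is therefore expected for compound 4, with a 1.2-fold higher number from compound 3 to compound 4 (0.06 log units; within the scatter) within the scatter. Compound 4 is estimated at 22 nM, between 10 nM and 50 nM.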

Compound 4, half-maximal inhibitory concentration: 9.4 nM
For compound 4 the middle estimate is 2.3-fold (0.37 log units) above the measured one; the measured number lies below the stated range.
By their numbers in this assay, from the lowest: compound 4; then compounds 3, 1 and 2 (each within the scatter of the next).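

In this assay, one added methyl, turning isopropoxy into tert-butoxy, gives the first step among these compounds that clears the scatter: a 2.0-fold lower number from compound 3 to compound 4 (0.31 log units; beyond the scatter). Compound 4 also stands apart from both sulfur-linked compounds, with a 2.3-fold lower number from compound 1 to compound 4 (0.37 log units; beyond the scatter) and a 3.9-fold lower number from compound 2 to compound 4 (0.60 log units; beyond the scatter), whereas the steps among compound 1, compound 2 and compound 3 all stayed within the scatter. Nothing available explains this difference.

Only isopropoxy and tert-butoxy are compared directly on the oxygen, so no trend with the size of this group can be drawn. From the compounds shown here alone, how methoxy, cyclohexyloxy or a longer chain such as n-butoxy would compare remains open.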